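Replacing 1H-pyrazol-1-yl with cyclopropyl in compound 3

A few compounds are considered here, and "the series" means these few. Any claim that something is new, unique, unknown or untested is made for them only; others in the source may bear on it.

Values measured in an ADME assay on microsomes from liver (Mus musculus, strain CD1) for metabolic stability, read by HPLC, using NADPH, with a stated time of 30 min; on this read-out higher numbers stand for fast clearance and lower numbers for slow clearance:

- Compound 1 `COc1cccc(NC(=O)c2nnn(Cc3cc(C)on3)c2N)c1`: 2.6 mL.min-1.g-1
- Compound 2 `COc1cccc(NC(=O)c2nnn(Cc3ccc(SC)cc3)c2N)c1`: 6.4 mL.min-1.g-1
- Compound 3 `COc1cccc(NC(=O)c2nnn(Cc3ccc(-n4cccn4)cc3)c2N)c1`: 2.3 mL.min-1.g-1

In this assay compound 3 gives 2.3 mL.min-1.g-1, within the usual scatter of compound 1 and clearly under compound 2. The next structure, compound 4 `COc1cccc(NC(=O)c2nnn(Cc3ccc(C4CC4)cc3)c2N)c1`, carries cyclopropyl in place of 1H-pyrazol-1-yl on an aromatic carbon, and the counted difference reads (cyclopropyl in place of 1H-pyrazol-1-yl on an aromatic carbon).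

The most relevant measurement comes from the same place on the molecule, where exchanging methylsulfanyl for 1H-pyrazol-1-yl gave a 2.8-fold lower number from compound 2 to compound 3 (0.44 log units; beyond the scatter). The other measured step, a 2.5-fold higher number from compound 1 to compound 2 (0.39 log units; beyond the scatter), changed the whole group on the saturated chain carbon, so it bears on this change only loosely, as a second modest step in the series.

Among the measured compounds shown here, no measured compound carries cyclopropyl, which leaves the size of the change uncertain. For the measured compounds named here, compound 2, the only measured compound without 1H-pyrazol-1-yl at that place among those sharing the six-membered aromatic ring, gives 6.4 mL.min-1.g-1, so a modest rise is expected on removing that group. The expected step is a 2.2-fold higher number from compound 3 to compound 4 (0.34 log units; beyond the scatter). For compound 4 the estimated value is 5 mL.min-1.g-1, with an expected range from 2.4 mL.min-1.g-1 to 10 mL.min-1.g-1.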

Compound 4, intrinsic clearance in microsomes in the Mus musculus assay: 4.9 mL.min-1.g-1
Beside the measured number, compound 4's estimate is 1.0-fold (0.01 log units) above it; the measured number falls inside the stated range.
By their numbers in the Mus musculus assay, from the lowest: compounds 3, 1, 4 and 2 (each within the scatter of the next, the first and the last beyond it).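

In the Mus musculus assay, cyclopropyl in place of 1H-pyrazol-1-yl gives a 2.1-fold higher number from compound 3 to compound 4 (0.33 log units; beyond the scatter), while cyclopropyl in place of methylsulfanyl gives a 1.3-fold lower number from compound 2 to compound 4 (0.12 log units; within the scatter), so of the three groups shown at this position, only 1H-pyrazol-1-yl goes with the lower number. Compared across the whole group on the saturated chain carbon, the Mus musculus assay shows a 1.9-fold higher number from compound 1 to compound 4 (0.28 log units; within the scatter), so 4-cyclopropylphenyl cannot be told apart from 5-methyl-1,2-oxazol-3-yl on this read-out. In a physicochemical assay for solubility, read by nephelometry, at pH 7.4 (a lower number here means a less soluble compound, a higher number a more soluble compound), compound 3 gives 20000 nM and compound 4 gives 79000 nM as measured values. The change also has a second side, since the exchange that raises the clearance number gives the more soluble compound in the physicochemical assay: the measured solubility of compound 3, 20000 nM, and of compound 4, 79000 nM, a 4.0-fold higher number (0.60 log units; beyond the scatter)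

The compounds shown leave open whether the lower clearance number belongs to 1H-pyrazol-1-yl itself or would also come with another aromatic ring at this place, such as pyridin-3-yl or 1H-imidazol-1-yl. They also leave open whether a saturated amine such as morpholin-4-yl could combine the clearance number of compound 3 with the solubility of compound 4.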